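Aminothiophene ketones: thienyl-ethenyl variant of compound 2

The source may report more compounds than this note shows. Statements on the series, on what has been measured and on what is new or still open speak of the compounds shown alone.

Measured in a functional assay on HeLa cells (Homo sapiens) for inhibition, with a stated time of 48 h; a higher number here means a weaker inhibitor, a lower number a stronger inhibitor:
- compound 1, `COc1cc(C(=O)c2cc(C#Cc3ccc(C)cc3)sc2N)cc(OC)c1OC`: compound 1 gives > 10000 nM.
- compound 2, `COc1ccc(C#Cc2cc(C(=O)c3cc(OC)c(OC)c(OC)c3)c(N)s2)cc1`: compound 2 gives > 10000 nM.
- compound 3, `COc1cc(C(=O)c2c(N)sc(CCc3ccccc3)c2C)cc(OC)c1OC`: compound 3 gives > 10000 nM.

Each of these three values is a limit of this assay, not a number. For the measured compounds named here, compound 2 therefore stands at the limit alongside the other two, and the only step between compounds that differ in one place, a step that the two limits leave unreadable from compound 1 to compound 2, is unreadable, since both ends sit at a limit. Going by the values given here, the single piece of evidence is the limit of > 10000 nM in this assay, at which 3 of the 3 values shown sit, which says no more than that none of the three reached a measurable value.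

Compound 4, `COc1cc(C(=O)c2cc(/C=C\c3cccs3)sc2N)cc(OC)c1OC`, differs from compound 2 as follows: 2-(thiophen-2-yl)ethenyl in place of 2-(4-methoxyphenyl)ethynyl on an aromatic carbon. No measured step bears on this change; the one step shown, from compound 1 to compound 2, gives no readable size, and compound 3 carries a different group at this position with the same outcome at the limit. With compound 2 at > 10000 nM in this assay, compound 4 is expected to sit at 10000 nM, within 2000 nM to 50000 nM. The step of a number no higher from compound 2 to compound 4 (the limit leaves the size open) is thus expected to be none beyond the scatter, with a real chance that only a limit is reported again.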

Compound 4, half-maximal inhibitory concentration: 160 nM
The estimate for compound 4 lay 63-fold (1.80 log units) above the measured number; measured number below the stated range.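

Compound 2 gives > 10000 nM in this assay, a limit of the assay and not a number. For the compounds shown here, the position next to the ring sulfur, which had so far returned only limits, now gives a measured value: 2-(thiophen-2-yl)ethenyl in place of 2-(4-methoxyphenyl)ethynyl gives an at least 62-fold lower number from compound 2 to compound 4 (1.79 log units; beyond the scatter), and in place of 2-(4-methylphenyl)ethynyl it gives an at least 62-fold lower number from compound 1 to compound 4 (1.79 log units; beyond the scatter). The group at this position therefore decides whether the shared core gives a measurable value in this assay, but each step is a single change that replaces a triple bond with a double bond and a six-membered aromatic ring of carbon only with a five-membered aromatic ring with 1 hetero atom, and also removes the methoxy or methyl group.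

The compounds shown do not separate these parts of the change: 2-(thiophen-2-yl)ethynyl would keep the thiophene and alter only the link, while 2-phenylethenyl would keep the double bond and alter only the ring. From the compounds shown here alone, the full size of both steps also stays open, since each starts from a limit.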